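A few compounds are considered here, and "the series" means these few. Any claim that something is new, unique, unknown or untested is made for them only; others in the source may bear on it.

Of the compounds shown here, three have so far been measured in a functional assay on T47D cells (Homo sapiens) for inhibition, read by sulforhodamine B assay, with a stated time of 48 h, tested at 0.01 uM; on this read-out lower numbers stand for a stronger effect and higher numbers for a weaker effect at the one concentration tested. Compound 1 `O=C(Nc1cccc(-n2cc(-c3ccncc3)c(-c3cc(O)cc(Cl)c3)n2)c1)Nc1ccc(Cl)c(Cl)c1` gives 106%. Compound 2 `COc1cc(Cl)cc(-c2nn(-c3cccc(NC(=O)Nc4cc(C(F)(F)F)cc(C(F)(F)F)c4)c3)cc2-c2ccncc2)c1` gives 96%. Compound 3 `COc1cc(Cl)cc(-c2nn(-c3cccc(NC(=O)Nc4ccc(Cl)c(Cl)c4)c3)cc2-c2ccncc2)c1` gives 94%, the lowest of the three numbers; against compound 2 it sits within the scatter, and only against compound 1 does it lie beyond it. Among the compounds with values here, the one change that can be followed directly is the step of a number 12 percentage points lower from compound 1 to compound 3 (beyond the scatter), a modest lowering of the number.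

Compound 4 `COc1cc(Cl)cc(-c2nn(-c3cccc(NC(=O)c4cccc(C(F)(F)F)c4)c3)cc2-c2ccncc2)c1` has not yet been measured. It differs from compound 3 in one place: 3-(trifluoromethyl)phenyl in place of (3,4-dichlorophenyl)amino on a carbonyl carbon. Seen one bond further out, a (3,4-dichlorophenyl)carbamoyl becomes a (3-(trifluoromethyl)phenyl)carbonyl.

Within the data shown here, no measured step touches this end of the molecule, so nothing bears on the change directly. Among the measured compounds shown here, the only hint is that compound 2 and compound 3, which carry different groups at this same end, give numbers within the scatter of each other, which suggests that this part of the structure has little sway on this assay. The step of a number 1 percentage points higher from compound 3 to compound 4 (within the scatter) is therefore expected to be small, in no clear direction. Compound 4 is expected to give 95% in this assay, with a likely range from 80% to 108%.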

Compound 4, a percentage reported as activity, at one concentration (the size of the read-out at that concentration, not a potency): 99%
Compound 4: the middle estimate sits 4 percentage points below what was measured; the range from low to high includes it.
By their numbers in this assay, from the lowest: compounds 3, 2, 4 and 1 (each within the scatter of the next, the first and the last beyond it).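

Within the data shown here, this is the first measured step at this end of the molecule, and in this assay replacing (3,4-dichlorophenyl)amino on the carbonyl carbon with 3-(trifluoromethyl)phenyl gives a number 5 percentage points higher from compound 3 to compound 4 (within the scatter). The group that leaves carries one hydrogen-bond donor and the group that enters carries none, so at this one concentration, losing that donor and the amide-type nitrogen's link to the aromatic ring produces no step beyond the usual scatter. No measurement shown here explains this result.

From the compounds shown here alone, it remains open whether any group on this carbonyl carbon can move the number beyond the scatter, for example a morpholine or a longer alkyl chain in place of 3-(trifluoromethyl)phenyl. Going by these compounds, since the read-out gives the size of the effect at one concentration and not a potency, it also remains open whether compound 3 and compound 4 would stay this close at other concentrations.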